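The compounds below may be only part of what the source reports. "The series", "measured", "known", "first", "only" and "open" are said of these compounds alone.

Working notes on the series sharing the core of compound 1 (`Nc1nc(N)c2cc(CSC(=S)N3CCN(C4CCCCC4)CC3)ccc2n1`). In a functional assay on A549 cells (Homo sapiens) for antiproliferative activity, read by MTT assay, with a stated time of 72 h (on this read-out lower numbers stand for stronger inhibition and higher numbers for weaker inhibition), compound 1 gives 4710 nM, compound 2 (`Nc1nc(N)c2cc(CSC(=S)N3CCN(c4ccc(O)cc4)CC3)ccc2n1`) gives 4210 nM and compound 3 (`Cc1ccc(N2CCN(C(=S)SCc3ccc4nc(N)nc(N)c4c3)CC2)cc1`) gives 2190 nM. The numbers span little. Among the measured compounds shown here, the only step beyond the scatter is a 2.2-fold lower number from compound 1 to compound 3 (0.33 log units; beyond the scatter), whereas a 1.1-fold lower number from compound 1 to compound 2 (0.05 log units; within the scatter) and a 1.9-fold lower number from compound 2 to compound 3 (0.28 log units; within the scatter) are not. Compound 3 thus separates from compound 1 but not from compound 2.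

Next is compound 4 (`Nc1nc(N)c2cc(CSC(=S)N3CCN(c4ccc(Cl)cc4)CC3)ccc2n1`), with the change chloro in place of methyl on an aromatic carbon, para to a large group, or 4-methylphenyl to 4-chlorophenyl. For the measured compounds named here, the closest precedent is the other swap on an aromatic carbon, a 1.9-fold lower number from compound 2 to compound 3 (0.28 log units; within the scatter), which stays within the scatter. The larger 2.2-fold lower number from compound 1 to compound 3 (0.33 log units; beyond the scatter) replaces the whole cyclohexyl group and says less about this change. Going by the values given here, no chloro compound has been measured, so the data give no firm direction. In this assay no step beyond the scatter is expected, and the estimated step is a 1.1-fold higher number from compound 3 to compound 4 (0.06 log units; within the scatter). For compound 4 the expected value is 2500 nM, with an estimated range of 1200 nM to 5000 nM.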

Compound 4, half-maximal inhibitory concentration: 5210 nM
For compound 4 the middle estimate is 2.1-fold (0.32 log units) below the measured one, outside the stated range (above it).
By their numbers in this assay, from the lowest: compounds 3, 2, 1 and 4 (each within the scatter of the next, the first and the last beyond it).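

In this assay this aromatic carbon, para to a large group, now gives a swap that clears the scatter: chloro in place of methyl gives a 2.4-fold higher number from compound 3 to compound 4 (0.38 log units; beyond the scatter) while the earlier swap at the same place gives a 1.9-fold lower number from compound 2 to compound 3 (0.28 log units; within the scatter) and stays within it. Chloro does not separate from hydroxy at this place, with a 1.2-fold higher number from compound 2 to compound 4 (0.09 log units; within the scatter) as the step, and 4-chlorophenyl does not separate from cyclohexyl on the amine nitrogen, with a 1.1-fold higher number from compound 1 to compound 4 (0.04 log units; within the scatter) as the step, so compound 3 alone stands apart from other compounds, from compound 1 and compound 4 but not from compound 2. No data on the cause of the step from methyl to chloro are at hand.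

Going by these compounds, with only methyl, hydroxy and chloro at this aromatic carbon, it remains open whether the separation of compound 3 from compound 4 is specific to methyl or would extend to other groups. A longer chain such as ethyl, or a methoxy or an amine at the same place on the shared core, would show whether the numbers in this assay move beyond this narrow span.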